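A few compounds are considered here, and "the series" means these few. Any claim that something is new, unique, unknown or untested is made for them only; others in the source may bear on it.

Series around the shared core of compound 1 `COc1ccc(-c2cc3ccccc3nc2C=O)cc1`, in which the formyl group on an aromatic carbon is extended into enone-linked aryl ketones. Antiproliferative potency is read in a functional assay on NCI-H460 cells (Homo sapiens) for antiproliferative activity, read by XTT assay, with a stated time of 72 h; on this read-out lower numbers stand for stronger inhibition and higher numbers for weaker inhibition. In this assay compound 1 gives only a limit, > 10000 nM, not a number. Compound 2 `COc1ccc(-c2cc3ccccc3nc2/C=C/C(=O)c2ccc([N+](=O)[O-])cc2)cc1` gives 6470 nM in this assay. Compound 3 `COc1ccc(-c2cc3ccccc3nc2/C=C/C(=O)c2ccco2)cc1` gives 6430 nM in this assay.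

Among the two numbers available, compound 2 has the highest number, with compound 3 nearest and separated by a 1.0-fold lower number from compound 2 to compound 3 (0.00 log units; within the scatter). The step from the formyl parent is an at least 1.5-fold lower number from compound 1 to compound 3 (0.19 log units; that floor lies within the scatter), a floor only, since compound 1 sits at a limit (the limit of > 10000 nM in this assay, at which 1 of the 3 values shown sits).

The unmeasured compound 4 `COc1ccc(-c2cc3ccccc3nc2/C=C/C(=O)c2c[nH]c3ccccc23)cc1` continues the variation of the aryl ketone. Relative to compound 2 the change is 1H-indol-3-yl in place of 4-nitrophenyl on a carbonyl carbon.

Among the measured compounds shown here, the one measured step that bears on this change, an exchange of the group on the carbonyl carbon, is a 1.0-fold lower number from compound 2 to compound 3 (0.00 log units; within the scatter), which did nothing beyond the scatter. With a 1H-indol-3-yl group the same behaviour is expected: a step of a 1.2-fold lower number from compound 2 to compound 4 (0.07 log units; within the scatter) in this assay, that is, no movement beyond the scatter. For compound 4 the expected value in this assay is therefore 5500 nM, with a range of 1800 nM to 16000 nM.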

Compound 4, half-maximal inhibitory concentration: 8010 nM
For compound 4 the middle estimate is 1.5-fold (0.16 log units) below the measured one; the range from low to high includes it.
By their numbers in this assay, from the lowest: compounds 3, 2 and 4 (each within the scatter of the next). At a limit, above all of these: compound 1.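

Working notes on the group on the carbonyl carbon in this assay: with 1H-indol-3-yl in place of 4-nitrophenyl, where a five-membered aromatic ring and a hydrogen-bond donor enter and the hydrogen-bond acceptors of the nitro group leave, the read-out gives a 1.2-fold higher number from compound 2 to compound 4 (0.09 log units; within the scatter), and in place of furan-2-yl it gives a 1.2-fold higher number from compound 3 to compound 4 (0.10 log units; within the scatter). Among the compounds shown here, the earlier pair compared only two groups, whereas the tolerance at this carbonyl carbon now extends to a third group of a different type, with a two-ring aromatic group and a monocyclic five-membered one both staying within the scatter of the 4-nitrophenyl compound. Nothing in the data accounts for this insensitivity.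

Still open, as far as these compounds go, is whether any group on this carbonyl carbon moves the number beyond the scatter, for instance an amine, a carboxylic acid or a longer alkyl chain in place of the aromatic groups. Also open, from the compounds shown here alone, is what the enone link itself adds, since compound 1 gives only a limit, > 10000 nM.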